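The source may hold more compounds than are shown below. What is called first, only, known or untested is meant among the compounds shown, and "the series" means these compounds.

Measured so far:
compound 1 `c1ccc(-c2nc3ccc(N4CCCCC4)nc3o2)cc1` gives 1370 nM in an assay on isolated protein for inhibition of Amine oxidase [flavin-containing] B (Homo sapiens), read by fluorescence, with a stated time of 1 h; on this read-out higher numbers stand for weaker inhibition and lower numbers for stronger inhibition;
compound 2 `Clc1cccc(-c2nc3ccc(N4CCCCC4)nc3o2)c1` gives 335 nM in this assay.

Among the compounds with values here, on these two numbers compound 1 stands highest; its nearest neighbour is compound 2, and the step of a 4.1-fold lower number from compound 1 to compound 2 (0.61 log units; beyond the scatter) is the only measured step. It shows that placing chloro on the phenyl ring of the shared core lowers the number to a modest but clear extent.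

Compound 3 `Clc1ccc(-c2nc3ccc(N4CCCCC4)nc3o2)cc1` is not yet measured. It differs from compound 1 by chloro in place of hydrogen on an aromatic carbon, that is, phenyl to 4-chlorophenyl. Within the data shown here, the one measured step that bears on this change is the step from compound 1 to compound 2, a chloro for hydrogen on the same phenyl ring, though not at the same position. A step of similar size and direction is therefore expected in this assay for compound 3, with the estimated step of a 3.4-fold lower number from compound 1 to compound 3 (0.53 log units; beyond the scatter), since no second chloro placement has yet been measured to show whether the position matters. Compound 3 is expected to come in at 400 nM, within a range of 150 nM to 1200 nM.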

Compound 3, half-maximal inhibitory concentration: 890 nM
For compound 3 the middle estimate is 2.2-fold (0.35 log units) below the measured one; the range from low to high includes it.
By their numbers in this assay, from the lowest: compound 2; then compounds 3 and 1 (each within the scatter of the next).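

In this assay, chloro on the aromatic carbon para to a large group does not separate compound 3 from the unsubstituted phenyl compound (a 1.5-fold lower number from compound 1 to compound 3 (0.19 log units; within the scatter)), so the effect seen with compound 2 does not carry over to 4-chlorophenyl. The placement of chloro on the phenyl ring therefore matters, since the two chloro isomers differ (a 2.7-fold higher number from compound 2 to compound 3 (0.42 log units; beyond the scatter)), with the placement in compound 2 giving the lower number. No measurement that would explain this dependence on placement is available.

With only two chloro placements shown, it remains open whether the difference belongs to chloro alone or extends to other groups. A fluoro, methyl or methoxy group at each of these two places would test this.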